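A few compounds are considered here, and "the series" means these few. Any claim that something is new, unique, unknown or untested is made for them only; others in the source may bear on it.

Compound 1 `COc1ccc(-n2ccnc2-c2cc(OC)c(OC)c(OC)c2)cc1[N+](=O)[O-]` and compound 2 `COc1ccc(-n2ccnc2-c2cc(OC)c(OC)c(OC)c2)cc1N` share one core, and in a functional assay on HT-29 cells (Homo sapiens) for antiproliferative activity, read by MTT assay, with a stated time of 72 h (on this read-out higher numbers stand for weaker inhibition and lower numbers for stronger inhibition), compound 1 gives 600 nM while compound 2 gives 200 nM. The change between them, (amino in place of nitro on an aromatic carbon), produced a 3.0-fold lower number from compound 1 to compound 2 (0.48 log units; beyond the scatter). Compound 3 `COc1ccc(C(=O)Nc2cc(OC)c(OC)c(OC)c2)cc1[N+](=O)[O-]` is built on a different core; the difference between the two cores is not broken down here. In this assay compound 3 gives 8300 nM, the highest number of the three measured compounds. Compound 4 `COc1ccc(C(=O)Nc2cc(OC)c(OC)c(OC)c2)cc1N` stands to compound 3 as compound 2 stands to compound 1: the change is amino in place of nitro on an aromatic carbon, at the same place. Its value in this assay is not yet known. The expectation for compound 4 rests on the one earlier step, since the step from compound 1 to compound 2 was a 3.0-fold lower number from compound 1 to compound 2 (0.48 log units; beyond the scatter) on the other core and nothing shown says whether the amide core behaves the same way. Going by the values given here, on that basis the step from compound 3 to compound 4 is expected to be about a 2.8-fold lower number from compound 3 to compound 4 (0.44 log units; beyond the scatter), with a wide margin because of a 3.0-fold lower number from compound 1 to compound 2 (0.48 log units; beyond the scatter) being the only precedent. Compound 4 is therefore estimated at 3000 nM, most likely between 1200 nM and 7500 nM.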

Compound 4, half-maximal inhibitory concentration: > 100000 nM
Compound 4 was reported as a limit; the forecaster's own chance of this, stated with the estimate: 5%; at least 33-fold (1.52 log units) between middle value and limit.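

In this assay, amino in place of nitro on an aromatic carbon did not carry over from one core to the other: the same change on two cores in this assay, a 3.0-fold lower number (0.48 log units; beyond the scatter) from compound 1 to compound 2 and an at least 12-fold higher number (1.08 log units; beyond the scatter) from compound 3 to compound 4, at least 36-fold (1.55 log units) apart, beyond the scatter of two such steps. On the core of compound 3 the change gives an at least 12-fold higher number from compound 3 to compound 4 (1.08 log units; beyond the scatter), so the step runs opposite to the one on the core of compound 1, and in these two pairs a step read on one core gave no reliable guide to the other. The value of compound 4, > 100000 nM, is a limit and not a number, so the full size of this step stays unread, and two pairs alone do not show why the cores part or whether the same reversal would hold in any further pair.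

The compounds shown leave open whether a methylamino or an acetamido group in place of the amino group would also separate the two cores. Going by these compounds, it also remains open whether a hydroxyl group or a fluorine atom on that same carbon would do so.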